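The source may hold more compounds than are shown below. What is called first, only, known or untested is meant among the compounds shown, and "the series" means these compounds.

Compound 1 `O=S(=O)(c1cccc(F)c1)c1ccc2c(c1)CCC[C@H]2CN1CCCS1(=O)=O`: 31.6 nM
Compound 2 `CN(C)C(=O)NC[C@@H]1CCCc2cc(S(=O)(=O)c3cccc(F)c3)ccc21`: 2.51 nM

Within the data shown here, in an assay on isolated protein for displacement of a labelled ligand from 5-hydroxytryptamine receptor 6 (Homo sapiens) (a higher number here means a weaker inhibitor, a lower number a stronger inhibitor), compound 2 gives 2.51 nM, the lower of the two numbers, while compound 1 gives 31.6 nM; the only measured step, a 13-fold lower number from compound 1 to compound 2 (1.10 log units; beyond the scatter), concerns a different part of the molecule. Compound 3 `COC(=O)NC[C@@H]1CCCc2cc(S(=O)(=O)c3cccc(F)c3)ccc21` differs from compound 2 by methoxy in place of dimethylamino on a carbonyl carbon. Among the measured compounds shown here, no measured step touches this carbonyl group, so the data give no size for this change, and only a modest shift, within or near the scatter, is expected. Compound 3 is therefore estimated at 5 nM, between 1.5 nM and 20 nM, which is expected to mean a step of a 2.0-fold higher number from compound 2 to compound 3 (0.30 log units; within the scatter).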

Compound 3, inhibition constant: 1.59 nM
Beside the measured number, compound 3's estimate is 3.1-fold (0.50 log units) above it, within the range that was stated.
By their numbers in this assay, from the lowest: compounds 3 and 2 (each within the scatter of the next); then compound 1.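

In this assay, methoxy on this carbonyl carbon reads the same as dimethylamino within the scatter (a 1.6-fold lower number from compound 2 to compound 3 (0.20 log units; within the scatter)), so this position accepts an oxygen-linked group as well as a nitrogen-linked one. The large difference from the ring group of compound 1 also remains with methoxy in place (a 20-fold lower number from compound 1 to compound 3 (1.30 log units; beyond the scatter)). Nothing available explains why these two groups read alike.

Still open, as far as these compounds go, is how a plain methyl, a longer ethoxy or a morpholine ring on this carbonyl carbon would read in this assay. The compounds shown also leave open whether the fluorine on the shared core matters to these numbers.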